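Hydroxyphenyl isomers in the series: compound 3 pending

The compounds below may be only part of what the source reports. "The series", "measured", "known", "first", "only" and "open" are said of these compounds alone.

Measured in a functional assay on HCT-116 cells (Homo sapiens) for inhibition, read by MTT assay, with a stated time of 48 h; on this read-out higher numbers stand for weaker inhibition and lower numbers for stronger inhibition:
compound 1 `COc1cc(-c2cc(-c3ccc(Br)cc3)nc(-c3ccccc3)n2)cc(OC)c1OC`: 4320 nM
compound 2 `COc1cc(-c2cc(-c3cccc(O)c3)nc(-c3ccccc3)n2)cc(OC)c1OC`: 20400 nM

Compound 2 holds the higher of the two numbers and is therefore the weaker of the pair. Compound 3 `COc1cc(-c2cc(-c3ccc(O)cc3)nc(-c3ccccc3)n2)cc(OC)c1OC` keeps the shared core and differs from compound 2 in one place: 4-hydroxyphenyl in place of 3-hydroxyphenyl on an aromatic carbon. The swap puts 4-hydroxyphenyl in place of 3-hydroxyphenyl on an aromatic carbon of a six-membered aromatic ring with 2 nitrogen.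

Among the measured compounds shown here, only one measured step bears on this, and only indirectly: a 4.7-fold higher number from compound 1 to compound 2 (0.67 log units; beyond the scatter). For the measured compounds named here, that step replaces 4-bromophenyl with 3-hydroxyphenyl, so it does not separate the two hydroxyphenyl isomers, and no measured pair does. Going by the values given here, with a 4.7-fold higher number from compound 1 to compound 2 (0.67 log units; beyond the scatter) as the only guide, a smaller step is expected here, leaning slightly towards a lower number, with no firm direction. The expected step is a 1.7-fold lower number from compound 2 to compound 3 (0.23 log units; within the scatter). For compound 3 the estimated value in this assay is 12000 nM, with an expected range of 4000 nM to 35000 nM.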

Compound 3, half-maximal inhibitory concentration: 11900 nM
Beside the measured number, compound 3's estimate is 1.0-fold (0.00 log units) above it; the range from low to high includes it.
By their numbers in this assay, from the lowest: compound 1; then compounds 3 and 2 (each within the scatter of the next).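

In this assay, moving the hydroxy group from 3-hydroxyphenyl to 4-hydroxyphenyl gives a 1.7-fold lower number from compound 2 to compound 3 (0.23 log units; within the scatter) and so does not separate the two isomers on this read-out. Hydroxy in place of bromo on an aromatic carbon, with no change in where the group sits on the phenyl ring, gives a 2.8-fold higher number from compound 1 to compound 3 (0.44 log units; beyond the scatter) and thus shows a step beyond the scatter without any shift in placement. Together with a 4.7-fold higher number from compound 1 to compound 2 (0.67 log units; beyond the scatter) this leaves compound 1 as the strongest of the three, and both hydroxyphenyl isomers go the same way against 4-bromophenyl, while no data on hand explain either step.

Open, on these data alone, is whether bromo itself matters here or whether another group in its place, such as chloro, an amine or a carboxylic acid, would give a number like that of compound 1 or a lower one. Also open, as far as these compounds go, is how much of the reading depends on the rest of the structure, since the phenyl group and the shared core stay the same in compound 1, compound 2 and compound 3.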